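This account rests on a few compounds, and the source may have more. Where it says the series, first, only, none or still open, it means among the compounds named here.

Measured so far in an ADME assay on MT4 cells (Homo sapiens) for cytotoxicity, read by MTT assay, with a stated time of 5 days; on this read-out lower numbers stand for higher toxicity in this test and higher numbers for lower toxicity in this test:
Compound 1 `Cc1cc(C#N)cc(C)c1Oc1nc(Nc2ccc(C#N)cc2)ncc1-c1cccnc1` gives 13500 nM.
Compound 2 `Cc1cc(C#N)cc(C)c1Oc1nc(Nc2ccc(C#N)cc2)ncc1-c1ccc2ccccc2c1` gives 8460 nM.

Compound 1 has the higher number of the two, which in this assay stands for the lesser toxicity, yet compound 2 lies only a 1.6-fold lower number from compound 1 to compound 2 (0.20 log units; within the scatter) away, so the two cannot be told apart. Compound 3 `Cc1ccc(-c2cnc(Nc3ccc(C#N)cc3)nc2Oc2c(C)cc(C#N)cc2C)cc1` is not yet measured. It differs from compound 1 in one place: 4-methylphenyl in place of pyridin-3-yl on an aromatic carbon. Among the compounds with values here, the only measured step that bears on this is the one in which pyridin-3-yl gave way to naphthalen-2-yl, another aromatic ring system of carbon only, and that step, a 1.6-fold lower number from compound 1 to compound 2 (0.20 log units; within the scatter), stayed within the scatter. On that basis no step beyond the scatter is expected from compound 1 to compound 3 in this assay, at most a slightly lower number. Compound 3 is therefore estimated at 10000 nM, with a range from 4000 nM to 25000 nM. This estimate corresponds to an expected step of a 1.4-fold lower number from compound 1 to compound 3 (0.13 log units; within the scatter).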

Compound 3, half-maximal cytotoxic concentration: 26100 nM
Beside the measured number, compound 3's estimate is 2.6-fold (0.42 log units) below it; measured number above the stated range.
By their numbers in this assay, from the lowest: compounds 2, 1 and 3 (each within the scatter of the next, the first and the last beyond it).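

The position tolerates more than one aromatic ring without a clear shift in this assay: 4-methylphenyl and pyridin-3-yl cannot be told apart (a 1.9-fold higher number from compound 1 to compound 3 (0.29 log units; within the scatter)), even though the ring nitrogen is gone and a methyl group has been added. Within the data shown here, the first step beyond the scatter appears between the two carbon-only ring systems (a 3.1-fold higher number from compound 2 to compound 3 (0.49 log units; beyond the scatter)), a modest gap that shows the choice of group here can move the number, with 4-methylphenyl on the side of lower toxicity in this test. Nothing available explains this gap.

On these data alone, it remains open whether an amine or a carboxylic acid on this ring would move the number further, and in which direction. As far as these compounds go, a plain ethyl chain in place of the ring is equally unexplored, so how much this position depends on having an aromatic ring at all is unknown.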